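Lengthening an Ester Chain and Cytotoxicity on Vero Cells

The source may report more compounds than this note shows. Statements on the series, on what has been measured and on what is new or still open speak of the compounds shown alone.

Three esters built on one shared core have been measured. In an ADME assay on Vero cells (Chlorocebus sabaeus) for cytotoxicity, read by MTT assay (on this read-out higher numbers stand for weaker inhibition and lower numbers for stronger inhibition), compound 1 `CCCCCCC(=O)OCC(C)(C)CC1=C(O)C(=O)c2ccccc2C1=O` gives 99300 nM. Compound 2 `CCCCCCCCC(=O)OCC(C)(C)CC1=C(O)C(=O)c2ccccc2C1=O` carries ethyl in place of hydrogen on a saturated chain carbon, six bonds along the chain from a carbonyl carbon, and in this assay compound 2 gives 150000 nM. Compound 3 `CCCCCCCCCCCCCC(=O)OCC(C)(C)CC1=C(O)C(=O)c2ccccc2C1=O` carries, relative to compound 1, (heptyl in place of hydrogen on a saturated chain carbon, six bonds along the chain from a carbonyl carbon), and compound 3 gives 58400 nM. Compound 4 `CCCCCCCCCCCCCCCC(=O)OCC(C)(C)CC1=C(O)C(=O)c2ccccc2C1=O` is not yet measured; it differs from compound 3 by ethyl in place of hydrogen on a saturated chain carbon, ten or more bonds along the chain from a carbonyl carbon. Going by the values given here, that is the same kind of change as the one from compound 1 to compound 2, at a different place along the chain. Because the earlier step was a 1.5-fold higher number from compound 1 to compound 2 (0.18 log units; within the scatter), compound 4 is expected to show a step of a 1.1-fold lower number from compound 3 to compound 4 (0.03 log units; within the scatter) from compound 3. Compound 4 is estimated at 55000 nM, expected between 22000 nM and 140000 nM.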

Compound 4, half-maximal inhibitory concentration: 4410 nM
Compound 4: middle estimate off by 12-fold (1.10 log units), on the high side; the whole stated range lies above it.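

The ethyl change does not carry over in size from one core to another: the same change on two cores in this assay, a 1.5-fold higher number (0.18 log units; within the scatter) from compound 1 to compound 2 and a 13-fold lower number (1.12 log units; beyond the scatter) from compound 3 to compound 4, 20-fold (1.30 log units) apart, beyond the scatter of two such steps. The heptyl change fails to carry over in the same way: the same change on two cores in this assay, a 1.7-fold lower number (0.23 log units; within the scatter) from compound 1 to compound 3 and a 34-fold lower number (1.53 log units; beyond the scatter) from compound 2 to compound 4, 20-fold (1.30 log units) apart, beyond the scatter of two such steps. The large steps, a 13-fold lower number from compound 3 to compound 4 (1.12 log units; beyond the scatter), a 34-fold lower number from compound 2 to compound 4 (1.53 log units; beyond the scatter) and a 23-fold lower number from compound 1 to compound 4 (1.35 log units; beyond the scatter), all lead to the longest chain shown, yet they do not reveal why the number falls so far or whether the fall is gradual or sudden along the chain.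

Going by these compounds, it remains open whether a longer chain would lower the number further in this assay. On these data alone, it is also open whether an amine placed on the ester chain would alter this picture.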